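Swapping (oxetan-2-yl)methyl for butyl in a cytotoxic series

A few compounds are considered here, and "the series" means these few. Any claim that something is new, unique, unknown or untested is made for them only; others in the source may bear on it.

Values in a functional assay on FaDu cells (Homo sapiens) for cytotoxicity, read by MTT assay, with a stated time of 72 h (on this read-out higher numbers stand for lower toxicity in this test and lower numbers for higher toxicity in this test), for the measured compounds
Compound 1 `CC(C)Oc1ccc(NC(=O)C(=O)c2cn(C(C)C)c3ccccc23)cn1` gives 408 nM
Compound 2 `COc1ccc(NC(=O)C(=O)c2cn(CC3CCO3)c3ccccc23)cn1` gives 686 nM
Compound 3 `CC(C)n1cc(C(=O)C(=O)Nc2ccc(C(F)(F)F)nc2)c2ccccc21` gives > 10000 nM and this is a limit of the assay, not a number

On these numbers, compound 2 at 686 nM and compound 1 at 408 nM lie within the usual scatter of each other. The next step leads from compound 2 to compound 4 `CCCCn1cc(C(=O)C(=O)Nc2ccc(OC)nc2)c2ccccc21`, which has not yet been measured. The change is propyl in place of oxetan-2-yl on a saturated chain carbon bound to an aromatic nitrogen. Read one bond further out, (oxetan-2-yl)methyl gives way to butyl.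

Among the measured compounds shown here, only one measured step is available, and it is large: an at least 24-fold higher number from compound 1 to compound 3 (1.38 log units; beyond the scatter). That step is trifluoromethyl in place of isopropoxy on an aromatic carbon, so it does not touch the place changed here and sets no size for this change. For the measured compounds named here, with no measured step at this place, the starting point stays compound 2 at 686 nM and no clear direction can be expected. The expected step is a 1.5-fold lower number from compound 2 to compound 4 (0.18 log units; within the scatter) and it is expected to stay within the usual scatter. Compound 4 is estimated at 450 nM in this assay with 120 nM to 1700 nM as the expected range.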

Compound 4, concentration lethal to 50% of the cells: 18 nM
Estimate against measurement, compound 4: 25-fold (1.40 log units) above; measured number below the stated range.
By their numbers in this assay, from the lowest: compound 4; then compounds 1 and 2 (each within the scatter of the next). At a limit, above all of these: compound 3.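

In this assay, replacing (oxetan-2-yl)methyl with butyl gives a 38-fold lower number from compound 2 to compound 4 (1.58 log units; beyond the scatter), so the group on a saturated chain carbon bound to an aromatic nitrogen clearly matters in this series. Among the compounds shown here, the only other measured step, an at least 24-fold higher number from compound 1 to compound 3 (1.38 log units; beyond the scatter), changes a group on an aromatic carbon, so this is the first sign that the nitrogen substituent can also shift the number by a large amount, here towards higher toxicity in this test. The change removes a four-membered ring with its oxygen and puts an open propyl in its place, but nothing shown explains why the number falls so far.

The compounds shown cannot separate the loss of the ring from the loss of the oxygen: cyclobutylmethyl would keep the ring without the oxygen, while 2-methoxyethyl would keep an oxygen without the ring. Going by these compounds, it also remains open whether a longer chain such as pentyl would push the number further, and whether butyl has the same effect alongside isopropoxy or trifluoromethyl in place of methoxy on the aromatic carbon.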